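This account rests on a few compounds, and the source may have more. Where it says the series, first, only, none or still open, it means among the compounds named here.

Compound 1 `OC[C@@H](O[C@H]1CCCN(Cc2ncc[nH]2)[C@H]1c1ccccc1)c1cc(Cl)cc(Cl)c1`: in an assay on isolated protein for activation of cGMP-dependent protein kinase 1 (Homo sapiens), read by ADP-Glo, with stated times of 30 min and 2 h (a higher number here means that more compound is needed for the effect, a lower number that less compound is needed), compound 1 gives > 200000 nM, a limit of the assay.
Compound 2 `O=C(O)c1ccc2nc(CN3CCC[C@H](O[C@H](CO)c4cc(Cl)cc(Cl)c4)[C@@H]3c3ccccc3)[nH]c2c1`: in this assay compound 2 gives 43000 nM.

Compound 2 holds the only number shown; the other value is a limit, namely (the limit of > 200000 nM in this assay, at which 1 of the 2 values shown sits). Compound 3 `Cc1nc(C(=O)O)ccc1CN1CCC[C@H](O[C@H](CO)c2cc(Cl)cc(Cl)c2)[C@@H]1c1ccccc1` differs from compound 2 by a group of 10 heavy atoms (7 carbon, 1 nitrogen, 2 oxygen; one six-membered aromatic ring with 1 hetero atom) in place of a group of 12 heavy atoms (8 carbon, 2 nitrogen, 2 oxygen; one five-membered aromatic ring with 2 hetero atoms, one six-membered aromatic ring of carbon only), on a saturated chain carbon bound to an amine nitrogen in a ring. Going by the values given here, one measured step bears on this position: an at least 4.6-fold lower number from compound 1 to compound 2 (0.66 log units; beyond the scatter), where the larger group carried the value out of the limit. The change to compound 3 leaves the group of similar size, so a step within or near the scatter is expected for compound 3, a 1.4-fold higher number from compound 2 to compound 3 (0.14 log units; within the scatter). Compound 3 is therefore estimated at 60000 nM, with a range from 15000 nM to 250000 nM.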

Compound 3, half-maximal effective concentration: 144000 nM
The estimate for compound 3 lay 2.4-fold (0.38 log units) below the measured number; the measured number falls inside the stated range.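

Replacing the group of 12 heavy atoms with the group of 10 heavy atoms gives a 3.3-fold higher number from compound 2 to compound 3 (0.52 log units; beyond the scatter), so at this position, on a saturated chain carbon bound to an amine nitrogen in a ring, similar size alone does not hold the number. Measured against the smallest group, the change reads an at least 1.3-fold lower number from compound 1 to compound 3 (0.14 log units; that floor lies within the scatter), so the group of 10 heavy atoms shows no gain beyond the scatter. Compound 1 stands at a limit of the assay: the limit of > 200000 nM in this assay, at which 1 of the 3 values shown sits.

The compounds shown leave open whether an amide in place of the carboxylic acid, or a longer chain leading to the ring, would move the number.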